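A few compounds are considered here, and "the series" means these few. Any claim that something is new, unique, unknown or untested is made for them only; others in the source may bear on it.

Measured in a functional assay, read by fluorescence and spectrophotometry, with a stated time of 1 h; a lower number here means that less compound is needed, a higher number that more compound is needed for the effect:
- compound 1 `O=S(=O)(/C=C/c1ccc(O)c(O)c1)CC1CCC1`: 8800 nM
- compound 2 `C=CCCCCCCS(=O)(=O)/C=C/c1ccc(O)c(O)c1`: 6400 nM
- compound 3 `CCCCCS(=O)(=O)/C=C/c1ccc(O)c(O)c1`: 8100 nM

Compound 3, at 8100 nM, cannot be told apart from the other two: a 1.1-fold lower number from compound 1 to compound 3 (0.04 log units; within the scatter) and a 1.3-fold higher number from compound 2 to compound 3 (0.10 log units; within the scatter) both stay within the scatter. Compound 4 `O=S(=O)(/C=C/c1ccc(O)c(O)c1)CC1CCCO1` changes a single group: oxolan-2-yl in place of butyl on a saturated chain carbon bound to a sulfonyl sulfur. In words, oxolan-2-yl stands in place of butyl on a saturated chain carbon bound to a sulfonyl sulfur.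

For the measured compounds named here, two measured steps bear on this place. Exchanging cyclobutyl for butyl gave a 1.1-fold lower number from compound 1 to compound 3 (0.04 log units; within the scatter), and exchanging cyclobutyl for hept-6-en-1-yl gave a 1.4-fold lower number from compound 1 to compound 2 (0.14 log units; within the scatter). Both are small, so among compounds 1, 2 and 3 this group has not visibly moved the number in this assay. Going by these compounds, none of these three compounds carries an oxygen in this group, so that part of the change is untested. No step beyond the scatter is therefore expected, though the uncertainty is wider than for a purely carbon group. The estimated step is a 1.0-fold higher number from compound 3 to compound 4 (0.02 log units; within the scatter). Compound 4 is expected at about 8500 nM, with an estimated range of 4000 nM to 18000 nM.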

Compound 4, half-maximal effective concentration: 10500 nM
For compound 4 the middle estimate is 1.2-fold (0.09 log units) below the measured one, and the stated range covers the measured number.
By their numbers in this assay, from the lowest: compounds 2, 3, 1 and 4 (each within the scatter of the next).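

In this assay, a group with a ring oxygen and a hydrogen-bond acceptor is now tested on a saturated chain carbon bound to a sulfonyl sulfur, and oxolan-2-yl stays within the scatter of all three earlier groups: a 1.3-fold higher number from compound 3 to compound 4 (0.11 log units; within the scatter) for butyl, a 1.6-fold higher number from compound 2 to compound 4 (0.22 log units; within the scatter) for hept-6-en-1-yl and a 1.2-fold higher number from compound 1 to compound 4 (0.08 log units; within the scatter) for cyclobutyl. Adding this oxygen, absent from compounds 1, 2 and 3, therefore brings no visible step in this set of four compounds. No measurement shown here explains this flat result.

Going by these compounds, whether an amine or a carboxylic acid at this place would give a step beyond the scatter remains open. On these data alone, it is also open whether an oxygen in an open chain, as in 2-methoxyethyl, would match the result for the ring.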